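A few compounds are considered here, and "the series" means these few. Any claim that something is new, unique, unknown or untested is made for them only; others in the source may bear on it.

In a functional assay (cardiac atrium) for agonist activity, with Cavia porcellus as the target (a higher number here means that more compound is needed for the effect, a lower number that less compound is needed), compound 2 `CC1=NC(C)=C([N+](=O)[O-])C(c2ccncc2)/C1=C(\O)OC(C)C` gives 8050 nM. Compound 1 `CC1=NC(C)=C([N+](=O)[O-])C(c2ccncc2)/C1=C(\O)OCC(C)C` gives 8510 nM in this assay, and the step of a 1.1-fold lower number from compound 1 to compound 2 (0.02 log units; within the scatter) puts the two within the scatter of each other, so neither can be called more potent. Compound 3 `CC1=NC(C)=C([N+](=O)[O-])C(c2ccccn2)/C1=C(\O)OC1CCCCC1` gives 3700 nM; 8450 nM (2 entries) in this assay, and the several entries of compound 3 in this assay, 3700 nM; 8450 nM (2 entries) shows how far repeated measurements of one compound can spread. Compound 4 `CC1=NC(C)=C([N+](=O)[O-])C(c2ccncc2)/C1=C(\O)OC(C)(C)C` differs from compound 2 by methyl in place of hydrogen on a saturated chain carbon bound to an oxygen on an unsaturated carbon and two saturated chain carbons. Within the data shown here, the only measured step touching this group, isopropyl in place of isobutyl on an oxygen on an unsaturated carbon, stayed within the scatter, and nothing here points to a larger shift. Compound 4 is therefore expected to show a 1.0-fold lower number from compound 2 to compound 4 (0.00 log units; within the scatter) in this assay, no step beyond the scatter. The estimate for compound 4 in this assay is 8000 nM, with a range from 3500 nM to 18000 nM.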

Compound 4, half-maximal effective concentration: 2820 nM
For compound 4 the middle estimate is 2.8-fold (0.45 log units) above the measured one, and the stated range ends above it.
By their numbers in this assay, from the lowest: compound 4; then compounds 2 and 1 (each within the scatter of the next).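

Isobutyl and isopropyl on this oxygen could not be told apart, but the added methyl on the saturated chain carbon gives a real shift in this assay, with a 2.9-fold lower number from compound 2 to compound 4 (0.46 log units; beyond the scatter). Tert-butyl in place of isobutyl gives a 3.0-fold lower number from compound 1 to compound 4 (0.48 log units; beyond the scatter), so the group on this oxygen can move the number. Both steps are modest, and repeated entries for a single compound can spread widely: the several entries of compound 3 in this assay, 3700 nM; 8450 nM (2 entries)

As far as these compounds go, whether a phenyl or neopentyl group on this oxygen would lower the number further remains open. So does whether tert-butyl would have the same effect on the core of compound 3.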